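A few compounds are considered here, and "the series" means these few. Any claim that something is new, unique, unknown or untested is made for them only; others in the source may bear on it.

Of the compounds shown here, three have so far been measured in an assay on isolated protein for inhibition of Leucine-rich repeat serine/threonine-protein kinase 2 variant G2019S (Homo sapiens), read by TR-FRET and LanthaScreen, with stated times of 50 min and 30 min, in the presence of a further agent that is not named here; on this read-out higher numbers stand for weaker inhibition and lower numbers for stronger inhibition. Compound 1 `C[C@@H]1CCCN1c1[nH]c2ncnc(N)c2c1C#N` gives 201 nM, compound 2 `C[C@@H]1CCCN1c1cc2c(N)ncnc2n1C` gives 6390 nM, and compound 3 `C[C@H]1CCCN1c1c(C#N)c2c(N)ncnc2n1C` gives 3080 nM. On these numbers compound 3 stands second highest of the three: its nearest neighbour is compound 2, whose number is higher by a margin beyond the scatter, and its furthest is compound 1, whose number is far lower, again beyond the scatter.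

Compound 4 `Cn1c(N)c(C#N)c2c(N)ncnc21` has not yet been measured. It differs from compound 3 in one place: amino in place of 2-methylpyrrolidin-1-yl on an aromatic carbon. The group that leaves counts six heavy atoms, the group that enters counts one. Going by the values given here, no pair of measured compounds shows this same change, so there is no measured step to calibrate against, and the expectation rests only on the shrinking of the substituent at that aromatic carbon.

Compound 4 is expected to give 8000 nM, with a range from 2000 nM to 30000 nM. The expected step of a 2.6-fold higher number from compound 3 to compound 4 (0.41 log units; beyond the scatter) points toward a higher number, beyond the scatter, though with little certainty.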

Compound 4, half-maximal inhibitory concentration: 8560 nM
Compound 4: the middle estimate sits 1.1-fold (0.03 log units) below what was measured; low and high end bracket the measured number.
By their numbers in this assay, from the lowest: compound 1; then compound 3; then compounds 2 and 4 (each within the scatter of the next).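

In this assay, going by these compounds alone, the replacement of 2-methylpyrrolidin-1-yl by amino gives the first measured change at this aromatic carbon: a 2.8-fold higher number from compound 3 to compound 4 (0.44 log units; beyond the scatter), a modest move toward weaker inhibition that lies beyond the scatter. Compound 4 still gives a finite number of 8560 nM with only amino in this place, so the five-membered non-aromatic ring is not needed for inhibition to be read in this assay, although compound 3, which has that ring, gives the lower number. No measurement at hand explains this step.

This reading rests on a single pair of compounds, so it cannot show whether the ring, its methyl group or simply the size of the group matters. Unsubstituted pyrrolidin-1-yl and dimethylamino at this carbon remain open, as does the same replacement on the core of compound 1.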